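Notes on the step from compound 3 to compound 4

The source may hold more compounds than are shown below. What is called first, only, known or untested is meant among the compounds shown, and "the series" means these compounds.

Measured so far in a functional assay on MKN-45 cells (Homo sapiens) for inhibition, with a stated time of 72 h; on this read-out lower numbers stand for stronger inhibition and higher numbers for weaker inhibition:
compound 1 `COc1ccc(S(=O)(=O)N2CCc3cccc(-c4ccc(N)cc4)c32)cc1` gives 162 nM
compound 2 `COc1ccc(S(=O)(=O)N2CCc3cccc(-c4ccco4)c32)cc1` gives 42 nM
compound 3 `COc1ccc(S(=O)(=O)N2CCc3cccc(-c4ccc(N(C)C)cc4)c32)cc1` gives 237 nM

Compound 3 stands with compound 1 at the weaker end of this small set, the two lying within the scatter of each other. Only compound 2 is clearly separated from it, with a 5.6-fold higher number from compound 2 to compound 3 (0.75 log units; beyond the scatter).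

Compound 4 `COc1ccc(S(=O)(=O)N2CCc3cccc(-c4ccc(F)cc4)c32)cc1` carries fluoro in place of dimethylamino on an aromatic carbon, para to a large group (fluoro in place of dimethylamino on an aromatic carbon).

Among the compounds with values here, the nearest evidence is a 1.5-fold higher number from compound 1 to compound 3 (0.17 log units; within the scatter), the only measured change made on this substituent, and it leaves the read-out unresolved. The other two steps exchange the whole substituted phenyl group for furan-2-yl. One is a 3.9-fold lower number from compound 1 to compound 2 (0.59 log units; beyond the scatter). The other is a 5.6-fold higher number from compound 2 to compound 3 (0.75 log units; beyond the scatter). Within the data shown here, both are modest, so changes at this place can move the number, but no fluoro compound has been measured as a guide. The two compounds with a nitrogen substituent both have higher numbers than compound 2, so a small move towards a lower number is expected, probably not beyond the scatter.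

The estimated step is a 1.8-fold lower number from compound 3 to compound 4 (0.26 log units; within the scatter). For compound 4 the expected value is 130 nM, with an estimated range from 50 nM to 300 nM.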

Compound 4, half-maximal inhibitory concentration: 79 nM
Beside the measured number, compound 4's estimate is 1.6-fold (0.22 log units) above it, within the range that was stated.
By their numbers in this assay, from the lowest: compounds 2 and 4 (each within the scatter of the next); then compounds 1 and 3 (each within the scatter of the next).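

In this assay, within the data shown here, the exchange between the two nitrogen groups had left this place on the phenyl ring unresolved, whereas fluoro gives the first change here that lies beyond the scatter, with a 3.0-fold lower number from compound 3 to compound 4 (0.48 log units; beyond the scatter) and a 2.1-fold lower number from compound 1 to compound 4 (0.31 log units; beyond the scatter). Both steps are modest, but they show that the substituent on this ring can move the number while the phenyl group stays in place, and the two nitrogen-bearing compounds share the higher numbers in this set. The phenyl group as such therefore no longer goes with the weaker end of the set, since a 1.9-fold higher number from compound 2 to compound 4 (0.27 log units; within the scatter) leaves the 4-fluorophenyl compound within the scatter of the furan-2-yl compound, though no measurement bears on why fluoro differs from the two nitrogen groups.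

Going by these compounds, it remains open whether this shift belongs to fluoro itself or would appear with any group lacking nitrogen, a question that chloro, methoxy or plain hydrogen at this place would help to settle. On these data alone, it is also open whether other five-membered rings, such as thiophen-2-yl, would stay level with furan-2-yl and 4-fluorophenyl or separate from them.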